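A Smaller Group on the Ring Amine Nitrogen

The source may hold more compounds than are shown below. What is called first, only, known or untested is meant among the compounds shown, and "the series" means these compounds.

Measured compounds:
- compound 1, `CCN(CC)c1ccc2cc(C(=O)c3ccc(N4CCN(C(=O)CN5CCN(S(=O)(=O)c6ccc(F)cc6)CC5)CC4)cc3)oc2c1`: > 40000 nM
- compound 2, `CCN(CC)c1ccc2cc(C(=O)c3ccc(N4CCN(C(=O)CN5CCN(Cc6ccc(C(F)(F)F)cc6)CC5)CC4)cc3)oc2c1`: > 40000 nM

In a functional assay on HCT-116 cells (Homo sapiens) for cytotoxicity, read by MTT assay, with a stated time of 48 h (on this read-out higher numbers stand for weaker inhibition and lower numbers for stronger inhibition), compound 1 gives > 40000 nM, which is a limit of the assay and not a number. In this assay compound 2 gives > 40000 nM, likewise a limit. The step that the two limits leave unreadable from compound 1 to compound 2 therefore cannot be read in size or direction, since the limit of > 40000 nM in this assay, at which 2 of the 2 values shown sit, holds both values. Compound 2 thus stands only at the limit, with no measured number of its own.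

Compound 3, `CCN(CC)c1ccc2cc(C(=O)c3ccc(N4CCN(C(=O)CN5CCN(CC(C)=O)CC5)CC4)cc3)oc2c1`, differs from compound 2 by acetyl in place of 4-(trifluoromethyl)phenyl on a saturated chain carbon bound to an amine nitrogen in a ring. Among the measured compounds shown here, the only measured step, from compound 1 to compound 2, bears on the same ring amine nitrogen but gives no readable size, so it offers no direction for the present change. Compound 3 is expected to remain at the limit as well, with an estimate of 50000 nM in this assay and a range from 15000 nM to 200000 nM. The expected step that the limit leaves unreadable from compound 2 to compound 3 is accordingly estimated as none beyond the scatter, with the real chance that compound 3 again returns only a limit.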

Compound 3, half-maximal inhibitory concentration: 24000 nM
Estimate against measurement, compound 3: 2.1-fold (0.32 log units) above; the measured number falls inside the stated range.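

In this assay compound 3 is the first compound shown to give a number and not a limit, 24000 nM, so this position on a saturated chain carbon bound to an amine nitrogen in a ring now has one readable end. Acetyl in place of 4-(trifluoromethyl)phenyl at this position gives an at least 1.6-fold lower number from compound 2 to compound 3 (0.22 log units; that floor lies within the scatter), and 2-oxopropyl in place of (4-fluorophenyl)sulfonyl on the amine nitrogen in the ring gives an at least 1.6-fold lower number from compound 1 to compound 3 (0.22 log units; that floor lies within the scatter). Both figures are floors only, which shows that a group without a ring at this place can go with a measured number, while the true size of each step remains unknown and the step between the two earlier compounds cannot be read: the limit of > 40000 nM in this assay, at which 2 of the 3 values shown sit.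

The compounds shown leave open whether the real difference from the two earlier compounds to compound 3 goes beyond the scatter, and whether the number of compound 3 goes with the carbonyl of the acetyl group or only with the loss of the aromatic ring. A 2-hydroxypropyl group or a plain propyl chain on the same amine nitrogen, or a carboxylic acid at the end of such a chain, would separate these two readings.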